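The source may hold more compounds than are shown below. What is called first, only, known or untested is meant among the compounds shown, and "the series" means these compounds.

Working notes on the series. Compound 1 `O=C(CSc1nnc(NC(=O)c2c(Cl)cccc2Cl)s1)Nc1ccc(Br)cn1` is one of three compounds with a number in a functional assay on HeLa cells (Homo sapiens) for antiproliferative activity, read by MTT assay, with a stated time of 48 h; on this read-out lower numbers stand for stronger inhibition and higher numbers for weaker inhibition; compound 1 gives 25800 nM, which is the highest of the two numbers shown. Compound 3 `O=C(CSc1nnc(NC(=O)CCl)s1)Nc1ccc(Cl)cn1` gives 3600 nM in this assay, a lower number than compound 1 by a margin beyond the scatter. Compound 2 `COc1ccccc1C(=O)Nc1nnc(SCC(=O)Nc2ccc(Cl)cn2)s1` reaches only the limit of this assay, reporting > 80000 nM and no number (the limit of > 80000 nM in this assay, at which 1 of the 3 values shown sits).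

Compound 4 `O=C(CSc1nnc(NC(=O)CCCl)s1)Nc1ccc(Br)cn1` differs from compound 1 in one place: 2-chloroethyl in place of 2,6-dichlorophenyl on a carbonyl carbon. Within the data shown here, the one measured step that bears on such a change is the one in which an aromatic group on that carbonyl carbon is exchanged for a short chlorinated chain: an at least 22-fold lower number from compound 2 to compound 3 (1.34 log units; beyond the scatter). From the compounds shown here alone, that step starts from a limit and not a number, so its true size is unknown beyond its lower bound, and the chain entering in compound 4 is 2-chloroethyl rather than chloromethyl. Among the measured compounds shown here, a step in the same direction, toward a lower number, is therefore expected, though no measured pair fixes how far a 2-chloroethyl goes. For compound 4 the estimate is 5000 nM, with a range from 1500 nM to 20000 nM. The expected step this implies is a 5.2-fold lower number from compound 1 to compound 4 (0.71 log units; beyond the scatter).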

Compound 4, half-maximal inhibitory concentration: 5300 nM
The estimate for compound 4 lay 1.1-fold (0.03 log units) below the measured number; the measured number falls inside the stated range.
By their numbers in this assay, from the lowest: compounds 3 and 4 (each within the scatter of the next); then compound 1. At a limit, above all of these: compound 2.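

In this assay, putting 2-chloroethyl in place of 2,6-dichlorophenyl on a carbonyl carbon whose other neighbour is an amide-type nitrogen gives a 4.9-fold lower number from compound 1 to compound 4 (0.69 log units; beyond the scatter). Among these compounds, this is the first step at this position with a number at both ends, and it runs in the same direction as an at least 22-fold lower number from compound 2 to compound 3 (1.34 log units; beyond the scatter), a step in another pair, with 2-methoxyphenyl leaving and chloromethyl entering. Compound 2 in that earlier step is a limit and not a number, so only the step from compound 1 to compound 4 has a known size: the limit of > 80000 nM in this assay, at which 1 of the 4 values shown sits.

Chloromethyl and 2-chloroethyl sit on compounds that also differ in a second place, so these two chains cannot be set against each other directly. Both steps remove an aromatic ring and bring in a chlorinated chain, which leaves open what a plain ethyl chain, a 3-chloropropyl chain or a chain ending in an amine instead of chlorine would give on this carbonyl carbon.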